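The compounds below may be only part of what the source reports. "The series", "measured", "known", "first", "only" and "open" are said of these compounds alone.

Compounds measured in a functional assay on KYSE-450 cells (Homo sapiens) for inhibition, read by MTT assay, with a stated time of 48 h; a higher number here means a weaker inhibitor, a lower number a stronger inhibitor:
compound 1 `COc1ccc(CN(C(=O)CCl)c2cc(OC)c(OC)c(OC)c2)cc1O` gives 210 nM
compound 2 `COC(=O)c1cc(CNc2cc(OC)c(OC)c(OC)c2)ccc1OC` gives 41100 nM
compound 3 `COc1ccc(CNc2cc(OC)c(OC)c(OC)c2)cc1F` gives 46200 nM

Compound 1 stands at the lowest number of the three; the nearest, compound 2, sits far above it, beyond the scatter, and compound 3 further still. Within the data shown here, the only single-point step among the measured compounds is a 1.1-fold higher number from compound 2 to compound 3 (0.05 log units; within the scatter), a change on an aromatic carbon that leaves the numbers of compound 2 and compound 3 side by side.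

Compound 4 `COc1ccc(CN(C(=O)CN=[N+]=[N-])c2cc(OC)c(OC)c(OC)c2)cc1O` differs from compound 1 by azido in place of chloro on a saturated chain carbon bound to a carbonyl carbon. Among the measured compounds shown here, no measured step touches this part of the molecule; the step between compound 2 and compound 3 concerns a different position and a different group, and the gap from compound 2 to compound 1 mixes several changes at once. The expectation for compound 4 therefore rests on compound 1 alone, with a broad range. A modest movement toward a higher number is expected for compound 4, a 2.4-fold higher number from compound 1 to compound 4 (0.38 log units; beyond the scatter), and compound 4 is estimated at 500 nM, between 120 nM and 3000 nM.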

Compound 4, half-maximal inhibitory concentration: 160 nM
Beside the measured number, compound 4's estimate is 3.1-fold (0.49 log units) above it, within the range that was stated.
By their numbers in this assay, from the lowest: compounds 4 and 1 (each within the scatter of the next); then compounds 2 and 3 (each within the scatter of the next).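

In this assay, azido in place of chloro on a saturated chain carbon bound to a carbonyl carbon gives a 1.3-fold lower number from compound 1 to compound 4 (0.12 log units; within the scatter) and so leaves the two compounds indistinguishable. Among these compounds, this is the first step read at this position, and it shows that the number of compound 1 does not depend on chloro as such: azido, with 3 heavy atoms where chloro has 1, is taken up here without a step beyond the scatter. Nothing at hand accounts for why the two groups read alike.

Open, as far as these compounds go, is whether an amine, a hydroxyl or a longer chain in place of chloromethyl would hold the number in the same way. Also open, from the compounds shown here alone, is what the whole (chloromethyl)carbonyl unit contributes on its own.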